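From 1H-imidazol-1-yl to 1H-1,2,4-triazol-1-yl on compound 1

This account rests on a few compounds, and the source may have more. Where it says the series, first, only, none or still open, it means among the compounds named here.

In an ADME assay on MCF7 cells (Homo sapiens) for cytotoxicity, read by MTT assay, with a stated time of 48 h (on this read-out higher numbers stand for weaker inhibition and lower numbers for stronger inhibition), compound 1 `Fc1ccc(-c2[nH]c3cc(F)ccc3c2Cn2ccnc2)cc1` gives 83200 nM and compound 2 `Fc1ccc2c(Cn3ccnc3)c(-c3ccc(Cl)cc3)[nH]c2c1` gives 45000 nM as its value, the two lying within the scatter of each other. Compound 3 `COc1ccc2c(Cn3ccnc3)c(-c3ccc(F)cc3)[nH]c2c1` reads > 1000000 nM as a limit of the assay, not a number. Compound 4 `Fc1ccc(-c2[nH]c3cc(F)ccc3c2Cn2cncn2)cc1` differs from compound 1 in one place (1H-1,2,4-triazol-1-yl in place of 1H-imidazol-1-yl on a saturated chain carbon bound to an aromatic carbon). Both measured steps sit on an aromatic carbon, not on this group: chloro in place of fluoro gave a 1.8-fold lower number from compound 1 to compound 2 (0.27 log units; within the scatter) and stayed small, while methoxy in place of fluoro gave an at least 12-fold higher number from compound 1 to compound 3 (1.07 log units; beyond the scatter) and was large. Neither tests the new change, so no step beyond the scatter is expected, and the estimated step is a 1.2-fold higher number from compound 1 to compound 4 (0.08 log units; within the scatter) with wide uncertainty. Compound 4 is expected at 100000 nM in this assay (estimated range 30000 nM to 400000 nM).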

Compound 4, half-maximal inhibitory concentration: > 1000000 nM
Compound 4: a limit, no number; the forecaster's own chance of this, stated with the estimate: 10%; at least 10-fold (1.00 log units) between middle value and limit.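

In this assay 1H-1,2,4-triazol-1-yl in place of 1H-imidazol-1-yl on a saturated chain carbon bound to an aromatic carbon gives an at least 12-fold higher number from compound 1 to compound 4 (1.07 log units; beyond the scatter) and so shows that a change at this place, not only on an aromatic carbon, can produce a large step. Compound 4 reads > 1000000 nM as a limit of the assay, not a number. The full size of the step therefore cannot be read: the limit of > 1000000 nM in this assay, at which 2 of the 4 values shown sit.

Open, from the compounds shown here alone, is how a 1H-pyrazol-1-yl group or an amine would read at this place. Also open, going by these compounds, is whether the triazolyl change gives a similar step with chloro on the aromatic carbon.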